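The compounds below may be only part of what the source reports. "The series", "measured", "known", "first", "only" and "open" are said of these compounds alone.

Compound 1 `N#Cc1c(N)cccc1Sc1ccccc1Cl` gives, in a functional assay on MT4 cells (Homo sapiens) for cytotoxicity (a higher number here means a weaker inhibitor, a lower number a stronger inhibitor), a value of 33000 nM. Compound 2 `N#Cc1c(N)cccc1Sc1ccccc1Br` carries the change (bromo in place of chloro on an aromatic carbon), and in this assay compound 2 gives 41000 nM; the step between them is a 1.2-fold higher number from compound 1 to compound 2 (0.09 log units; within the scatter). Compound 3 `N#Cc1c(N)cccc1S(=O)(=O)c1ccc(Cl)cc1` is built on a different core; how that core differs from the core of compound 1 is not broken down here. In this assay compound 3 reaches only a limit of the assay, > 5000 nM, not a number. That is the limit of > 5000 nM in this assay, at which 1 of the 3 values shown sits. Within the data shown here, compound 4 `N#Cc1c(N)cccc1S(=O)(=O)c1ccc(Br)cc1` carries the change (bromo in place of chloro on an aromatic carbon), the same kind of change as the one from compound 1 to compound 2, though there the group stands ortho to a large group and here para to a large group. The step expected for compound 4 is a step that the limit leaves unreadable from compound 3 to compound 4, resting on a 1.2-fold higher number from compound 1 to compound 2 (0.09 log units; within the scatter), which stayed within the scatter. Since compound 3 gave only > 5000 nM, a limit is likely again. For compound 4 the expected value is 10000 nM, within a range from 3000 nM to 50000 nM.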

Compound 4, half-maximal inhibitory concentration: > 200000 nM
Compound 4 gave a limit, no number; the forecaster's own chance of this, stated with the estimate: 70%; middle value at least 20-fold (1.30 log units) from the limit.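

In this assay compound 3 gives > 5000 nM, a limit and not a number. Compound 4 gives > 200000 nM, also a limit, so no step can be read between compound 3 and compound 4. The compounds shown leave open what bromo in place of chloro, para to a large group, does to the number in this assay.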